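A few compounds are considered here, and "the series" means these few. Any claim that something is new, unique, unknown or untested is made for them only; others in the source may bear on it.

Measured compounds in the series:

- compound 1 `O=C(Nc1cccc(-n2cc(-c3ccncc3)c(-c3cc(O)cc(Cl)c3)n2)c1)Nc1ccc(Cl)c(Cl)c1`: 93%
- compound 2 `COc1cc(Cl)cc(-c2nn(-c3cccc(NC(=O)Nc4ccc(Cl)c(C(F)(F)F)c4)c3)cc2-c2ccncc2)c1`: 93%

In a functional assay on MDA-MB-435 cells (Homo sapiens) for inhibition, read by sulforhodamine B assay, with a stated time of 48 h, tested at 0.1 uM (on this read-out lower numbers stand for a stronger effect and higher numbers for a weaker effect at the one concentration tested), compound 1 gives 93%. In this assay compound 2 gives 93%, level with compound 1 at the digits reported; its nearest neighbour is compound 1 and the two do not differ beyond the scatter of the read-out. For the measured compounds named here, no pair of measured compounds differs in a single place, so no measured single-point step is available in this assay.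

Compound 3 `COc1cc(Cl)cc(-c2nn(-c3cccc(NC(=O)Nc4ccc(Cl)c(Cl)c4)c3)cc2-c2ccncc2)c1` has not yet been measured in this assay. It differs from compound 2 by one change: chloro in place of trifluoromethyl on an aromatic carbon. Going by the values given here, since compound 2 gives 93% and nothing measured so far separates the two chlorophenyl urea ends beyond the scatter, no step beyond the scatter is expected from compound 2 to compound 3; the expected step is a number 1 percentage points lower from compound 2 to compound 3 (within the scatter). For compound 3 the estimate in this assay is 92%, with a range from 82% to 100%.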

Compound 3, a percentage reported as activity, at one concentration (the size of the read-out at that concentration, not a potency): 99%
Beside the measured number, compound 3's estimate is 7 percentage points below it; the range from low to high includes it.
By their numbers in this assay, from the lowest: compounds 1, 2 and 3 (each within the scatter of the next).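

In this assay, for the compounds shown here, chloro in place of trifluoromethyl on an aromatic carbon, ortho to a chloro group and meta to a large group, gives a number 6 percentage points higher from compound 2 to compound 3 (within the scatter), the first single-place reading at this position; neither group separates from the other here. Methyl in place of hydrogen on an oxygen on an aromatic ring gives a number 6 percentage points higher from compound 1 to compound 3 (within the scatter), so this second place also shows no step beyond the scatter at the one concentration tested. Nothing available explains either reading.

Still open, as far as these compounds go, is whether an amine or a carboxylic acid on the same aromatic carbon would move the read-out in this assay beyond the scatter. A single concentration also leaves open whether these changes would separate at any other concentration.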